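Trading a Trifluoromethoxy Group for Fluoro in Compound 2

A few compounds are considered here, and "the series" means these few. Any claim that something is new, unique, unknown or untested is made for them only; others in the source may bear on it.

Among the measured compounds shown here, compound 2 `FC(F)(F)Oc1ccc(Oc2ccnc(N3CCC(NC(=S)Nc4cccnc4)CC3)c2)cc1` is the stronger of the two compounds measured so far in an assay on membranes from brain for binding affinity to Lysophosphatidylserine lipase ABHD12 (Mus musculus), read by fluorescence, with a stated time of 20 min; on this read-out lower numbers stand for stronger inhibition and higher numbers for weaker inhibition: compound 2 gives 410 nM, while compound 1 `FC(F)(F)Oc1ccc(Oc2ccnc(N3CCC(NC(=S)Nc4cccnc4)CC3)c2C(F)(F)F)cc1` gives 2800 nM. For the measured compounds named here, the one measured step, a 6.8-fold lower number from compound 1 to compound 2 (0.83 log units; beyond the scatter), concerns a change on the shared core and says nothing about the outer ring that is altered here.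

Compound 3 `Fc1ccc(Oc2ccnc(N3CCC(NC(=S)Nc4cccnc4)CC3)c2)cc1` differs from compound 2 only at that outer ring: fluoro in place of trifluoromethoxy on an aromatic carbon. Going by the values given here, no measured step bears on this place, so the expectation rests on the change alone. A small group replacing a larger one at a position that evidently matters in such series is expected to give a modest loss, a 2.2-fold higher number from compound 2 to compound 3 (0.34 log units; beyond the scatter), though a result within the scatter would not surprise.

Compound 3 is therefore estimated at 900 nM, with a plausible range from 250 nM to 3200 nM.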

Compound 3, half-maximal inhibitory concentration: 1400 nM
The estimate for compound 3 lay 1.6-fold (0.19 log units) below the measured number; low and high end bracket the measured number.
By their numbers in this assay, from the lowest: compound 2; then compounds 3 and 1 (each within the scatter of the next).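

The outer ring is not a silent spot: with fluoro in place of trifluoromethoxy at this place, para to a large group, this assay shows a 3.4-fold higher number from compound 2 to compound 3 (0.53 log units; beyond the scatter). Among the compounds shown here, until now, the only measured change lay on the shared core, so this is the only evidence that the group at the far end of the molecule also affects the number. Here, trifluoromethoxy gives the stronger inhibition of the two groups. Nothing available explains why these two groups differ.

As far as these compounds go, two groups at one place cannot establish a trend, so it remains open how a methoxy group, a chloro group or a plain hydrogen would compare there. From the compounds shown here alone, it is also open whether the same swap would give a step of similar size on the core of compound 1, which carries trifluoromethyl.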